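Moving the nitrophenyl group: compound 3 to compound 4

This account rests on a few compounds, and the source may have more. Where it says the series, first, only, none or still open, it means among the compounds named here.

In a functional assay on HSC-4 cells (Homo sapiens) for cytotoxicity, with a stated time of 24 h (on this read-out higher numbers stand for lower toxicity in this test and lower numbers for higher toxicity in this test), compound 3 (`COc1cc(/C=C2\CCC/C(=C\c3cccc([N+](=O)[O-])c3)C2=O)cc(OC)c1OC`) reads 92000 nM as the highest of three numbers. Compound 2 (`COc1cc(/C=C2\CCC/C(=C\c3ccccc3[N+](=O)[O-])C2=O)cc(OC)c1OC`) reads 6500 nM and compound 1 (`O=C1/C(=C/c2ccc(F)cc2)CCC/C1=C\c1ccccc1[N+](=O)[O-]`) reads 2200 nM on the same test.

Compound 4 (`COc1cc(/C=C2\CCC/C(=C\c3ccc([N+](=O)[O-])cc3)C2=O)cc(OC)c1OC`) keeps the shared core of compound 3 and differs in one place (4-nitrophenyl in place of 3-nitrophenyl on a double-bonded chain carbon bound to a double-bonded ring carbon): 4-nitrophenyl in place of 3-nitrophenyl on a double-bonded chain carbon bound to a double-bonded ring carbon.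

Going by the values given here, the one measured step that bears on this change is 3-nitrophenyl in place of 2-nitrophenyl (a 14-fold higher number from compound 2 to compound 3 (1.15 log units; beyond the scatter)), which was large and beyond the scatter. A single step sets no trend, but it shows that this assay can respond strongly to this kind of swap. Compound 3 also stands at the top of the range, so a lower number is expected, though by less than that step. The expected step is a 3.1-fold lower number from compound 3 to compound 4 (0.49 log units; beyond the scatter) with wide uncertainty. The estimate for compound 4 is 30000 nM (estimated range 6000 nM to 120000 nM).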

Compound 4, half-maximal cytotoxic concentration: 1500 nM
The estimate for compound 4 lay 20-fold (1.30 log units) above the measured number; the whole stated range lies above it.
By their numbers in this assay, from the lowest: compounds 4 and 1 (each within the scatter of the next); then compound 2; then compound 3.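

In this assay, the place on a double-bonded chain carbon bound to a double-bonded ring carbon now has three nitrophenyl isomers behind it, and the response does not run in one direction. The a 61-fold lower number from compound 3 to compound 4 (1.79 log units; beyond the scatter) more than undoes a 14-fold higher number from compound 2 to compound 3 (1.15 log units; beyond the scatter) seen earlier, so 3-nitrophenyl stands out as the high reading rather than marking a trend. The a 4.3-fold lower number from compound 2 to compound 4 (0.64 log units; beyond the scatter) also places 4-nitrophenyl lowest among compounds 2, 3 and 4.

Both groups have identical counts, and nothing at hand accounts for the swing.

Still open, from the compounds shown here alone, is whether the high reading belongs to the nitro group itself or to any group in that ring position, which a 3-aminophenyl or 3-carboxyphenyl group would test. Going by these compounds, whether 4-nitrophenyl keeps its low reading with a different partner on the shared core also remains unknown.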